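The compounds below may be only part of what the source reports. "The series", "measured", "known", "first", "only" and "open" are said of these compounds alone.

Measured so far:
compound 1, `Cc1c(C(C)C)c(=O)on1C(=O)N1CCCCC1C` — 93 nM
compound 2, `COCCc1c(C)n(C(=O)N2CCC(c3cccc(F)c3)CC2)oc1=O` — 20 nM
compound 3, `CSc1nc(-c2ccc(Cl)cc2)nn1C(=O)N1CCCCC1` — 1.76 nM

In an assay (strain Wistar) for inhibition of Hormone-sensitive lipase (Rattus norvegicus), read by spectrophotometry (on this read-out lower numbers stand for stronger inhibition and higher numbers for weaker inhibition), compound 1 gives 93 nM and compound 2 gives 20 nM. In this assay compound 3 gives 1.76 nM, the lowest number of the three; its gap to compound 2 and its larger gap to compound 1 both lie beyond the usual scatter. The three compounds differ at several places at once, so nothing in the series ties a single change to a single step.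

Compound 4, `O=C(N1CCCCC1)n1nc(-c2ccc(Cl)cc2)nc1SCC1CC1`, has not yet been measured in this assay. It differs from compound 3 in one place: cyclopropyl in place of hydrogen on a saturated chain carbon bound to a sulfur. Read one bond further out, methylsulfanyl becomes (cyclopropylmethyl)sulfanyl. Going by the values given here, no pair of measured compounds covers a change of this kind, so the size of the step in this assay cannot be read from the series. A small step is expected, in either direction, not beyond the scatter; the expected step is a 1.4-fold higher number from compound 3 to compound 4 (0.15 log units; within the scatter). Compound 4 is accordingly expected to give about 2.5 nM in this assay, with a range from 0.6 nM to 10 nM.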

Compound 4, half-maximal inhibitory concentration: 3.53 nM
For compound 4 the middle estimate is 1.4-fold (0.15 log units) below the measured one; measured number inside the range.
By their numbers in this assay, from the lowest: compounds 3 and 4 (each within the scatter of the next); then compound 2; then compound 1.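

In this assay, the step of a 2.0-fold higher number from compound 3 to compound 4 (0.30 log units; within the scatter) gives the series its first reading of a single change, and that reading lies within the scatter. At this position, on a saturated chain carbon bound to a sulfur, methylsulfanyl and (cyclopropylmethyl)sulfanyl therefore cannot be told apart, even though the change adds a three-membered ring of 3 carbon heavy atoms. No supporting measurement is available to explain this result.

This single pair leaves open how far the position stays insensitive, since it gives no reading for a longer chain, an amine or a carboxylic acid at the same place. It also cannot show whether the same change would give a similar step on the other cores in the series.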